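Trading bromo for trifluoromethyl in compound 3

The source may report more compounds than this note shows. Statements on the series, on what has been measured and on what is new or still open speak of the compounds shown alone.

Of the compounds shown here, three with closely related structures have been measured so far. In a functional assay on the whole organism for antagonist activity, with Rattus norvegicus as the target (on this read-out higher numbers stand for an effect only at larger amounts of compound and lower numbers for an effect already at smaller amounts), compound 1 `Oc1nc2cc(Br)c(Cl)nc2nc1O` gives 20 mg/kg as its result, compound 2 `Oc1nc2cc(C(F)(F)F)cnc2nc1O` gives 13 mg/kg as its result, and compound 3 `[O-][n+]1c(Cl)c(Br)cc2nc(O)c(O)nc21` gives 18 mg/kg as its result. Compound 3 sits within the usual scatter of both compound 1 and compound 2, so these three numbers cannot be ranked.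

Compound 4 `[O-][n+]1c(Cl)c(C(F)(F)F)cc2nc(O)c(O)nc21` has not been measured yet. It differs from compound 3 in one place, with trifluoromethyl in place of bromo on an aromatic carbon that is ortho to a chloro group. Going by the values given here, no measured pair isolates this change. The closest hint is indirect and comes from two compounds that differ in more than this group. Compound 2 carries trifluoromethyl and gives 13 mg/kg as its result, within the scatter of compound 1, which carries bromo and gives 20 mg/kg as its result. In this assay the expected step is a 1.3-fold lower number from compound 3 to compound 4 (0.11 log units; within the scatter) towards a lower number, which would stay within the scatter. The expected value for compound 4 is 14 mg/kg within an estimated range of 6 mg/kg to 32 mg/kg in this measurement.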

Compound 4, dose for half-maximal effect: 30 mg/kg
Compound 4: the middle estimate sits 2.1-fold (0.33 log units) below what was measured, within the range that was stated.
By their numbers in this assay, from the lowest: compounds 2, 3, 1 and 4 (each within the scatter of the next, the first and the last beyond it).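

In this assay, going by these compounds alone, this is the first comparison that changes only the group at this position, and the swap gives a 1.7-fold higher number from compound 3 to compound 4 (0.22 log units; within the scatter) and so cannot be read as a real loss or gain. The position, ortho to a chloro group and two atoms from the ring nitrogen, therefore holds trifluoromethyl with its 4 heavy atoms in place of bromo with its 1 heavy atom, without a step beyond the usual scatter. Nothing available bears on why the number comes out this way.

As far as these compounds go, whether an amine, a nitrile or a carboxylic acid at this position would also stay within the scatter of compound 3 remains open. No pair shown tests the same swap on a different core, so it is also unknown whether this step carries over.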